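Series notes: aryl swap at the distal ring in compound 1

This account rests on a few compounds, and the source may have more. Where it says the series, first, only, none or still open, it means among the compounds named here.

Compound 1 `COc1ccc(-c2ccc(C(O)(c3c[nH]cn3)C(C)C)cc2)cc1` is the reference point here. For the measured compounds named here, in an assay on microsomes from Testis (strain Sprague-Dawley) for inhibition of steroid 17-alpha-hydroxylase/17,20 lyase (Rattus norvegicus) (a higher number here means a weaker inhibitor, a lower number a stronger inhibitor), compound 1 gives 120 nM, the highest of the three numbers measured so far. Compound 3 `CNS(=O)(=O)c1cccc(-c2ccc(C(O)(c3c[nH]cn3)C(C)C)cc2)c1` gives 71 nM in this assay, within the scatter of compound 1, so no order between the two can be read. Compound 2 `CC(=O)Nc1cccc(-c2ccc([C@](O)(c3c[nH]cn3)C(C)C)cc2)c1` gives 14 nM in this assay, a clearly lower number than compound 1, beyond the scatter. Going by the values given here, no single-point step between measured compounds is available, so the effect of changing the distal aromatic group on the shared core rests on these three numbers only.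

Compound 4 `CC(C)C(O)(c1ccc(-c2ccccn2)cc1)c1c[nH]cn1` differs from compound 1 in one place: pyridin-2-yl in place of 4-methoxyphenyl on an aromatic carbon. The distal group stays aromatic and keeps one hydrogen-bond acceptor, but the ring is smaller and carries a ring nitrogen. Among the compounds with values here, nothing among the measured compounds tests this kind of change, so no step beyond the scatter is expected in either direction; the estimated step is a 1.1-fold lower number from compound 1 to compound 4 (0.04 log units; within the scatter). For compound 4 the estimate in this assay is 110 nM, with a range from 30 nM to 400 nM.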

Compound 4, half-maximal inhibitory concentration: 210 nM
Beside the measured number, compound 4's estimate is 1.9-fold (0.28 log units) below it; the measured number falls inside the stated range.
By their numbers in this assay, from the lowest: compound 2; then compounds 3, 1 and 4 (each within the scatter of the next, the first and the last beyond it).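

Pyridin-2-yl in place of 4-methoxyphenyl gives the first single-point step in the series: in this assay the change is a 1.8-fold higher number from compound 1 to compound 4 (0.24 log units; within the scatter) and leaves no order to be read between the two compounds. On this aromatic carbon, para to a large group, a smaller distal ring carrying a ring nitrogen therefore stays within the scatter of the 4-methoxyphenyl reference, so this single swap does not separate the two groups. No measurement at hand bears on the reason for this result.

The compounds shown leave open whether plain phenyl, pyridin-3-yl or pyridin-4-yl at this place would stay within the scatter of compound 1. They also leave open what a pyridin-2-yl ring carrying a methoxy group or an amine would give.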